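The compounds below may be only part of what the source reports. "The series", "measured", "known", "first", "only" and "open" are said of these compounds alone.

Measured so far:
compound 1 `COc1cccc([C@H](O)[C@H]2CO[C@H](c3ccc(OC)c(OC)c3)[C@@H](C/C=C/c3ccc(OC)c(OC)c3)C2)c1` gives 21200 nM in a functional assay on HeLa cells (Homo sapiens) for cytotoxicity, read by WST assay, with a stated time of 48 h; on this read-out lower numbers stand for stronger inhibition and higher numbers for weaker inhibition;
compound 2 `COc1cccc(/C=C/C[C@@H]2C[C@@H]([C@@H](O)c3ccc(OC)c(OC)c3)CO[C@H]2c2ccc(OC)c(OC)c2)c1` gives 16400 nM in this assay.

On these two numbers compound 2 and compound 1 sit within the usual scatter of each other, so neither can be told apart from the other. Compound 3 `COc1ccc(/C=C/C[C@@H]2C[C@@H]([C@@H](O)c3ccc(OC)c(OC)c3)CO[C@H]2c2ccc(OC)c(OC)c2)cc1OC` has not been measured. It differs from compound 2 by one change: methoxy in place of hydrogen on an aromatic carbon. Within the data shown here, no comparable step between measured compounds is available. The change turns a 3-methoxyphenyl into a 3,4-dimethoxyphenyl, and for compound 3 the expected step of a 1.2-fold lower number from compound 2 to compound 3 (0.07 log units; within the scatter) is small, not beyond the scatter in either direction. For compound 3 the estimated value in this assay is 14000 nM, with a range of 6000 nM to 35000 nM.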

Compound 3, half-maximal inhibitory concentration: 30600 nM
For compound 3 the middle estimate is 2.2-fold (0.34 log units) below the measured one; the range from low to high includes it.
By their numbers in this assay, from the lowest: compounds 2, 1 and 3 (each within the scatter of the next).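

In this assay, among these compounds, replacing hydrogen with methoxy on this aromatic carbon, ortho to a methoxy group and para to a large group, gives a 1.9-fold higher number from compound 2 to compound 3 (0.27 log units; within the scatter), the first measured step at this position. This change, from 3-methoxyphenyl to 3,4-dimethoxyphenyl, therefore cannot be told apart from repeat-measurement noise. Nothing available accounts for the result.

Still open, as far as these compounds go, is whether a different group on this carbon, such as an amine, a carboxylic acid or a fluorine atom, would give a step beyond the scatter.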